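The source may report more compounds than this note shows. Statements on the series, on what has been measured and on what is new or still open speak of the compounds shown alone.

Working notes on the series. In a functional assay on MCF7 cells (Homo sapiens) for cytotoxicity, read by MTT assay, with a stated time of 72 h (a higher number here means a weaker inhibitor, a lower number a stronger inhibitor), compound 1 `Cc1cc(N2CCCCC2)nc(SCc2nc3ccccc3[nH]2)n1` gives > 100000 nM, which is a limit. Compound 2 `Cc1cc(N2CCNCC2)nc(SCc2nc3ccccc3[nH]2)n1` gives > 100000 nM, which is also a limit. Neither compound has a number of its own: both stand at the limit of > 100000 nM in this assay, at which 2 of the 2 values shown sit.

Compound 3 `Cc1cc(Nc2ccc(F)cc2)nc(SCc2nc3ccccc3[nH]2)n1` carries (4-fluorophenyl)amino in place of piperazin-1-yl on an aromatic carbon, next to the ring nitrogen: (4-fluorophenyl)amino in place of piperazin-1-yl on an aromatic carbon. Among the compounds with values here, the only measured step bearing on this position is a step that the two limits leave unreadable from compound 1 to compound 2, piperazin-1-yl in place of piperidin-1-yl, and it gives no size to carry forward. The expectation therefore rests on the structural change alone, and it stays loose. In this assay the expected step is an at least 2.5-fold lower number from compound 2 to compound 3 (0.39 log units; beyond the scatter), toward a stronger inhibitor, though compound 3 may well stay at the limit too. Compound 3 is estimated at 40000 nM, with an expected range of 8000 nM to 100000 nM.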

Compound 3, half-maximal inhibitory concentration: 42200 nM
Compound 3: the middle estimate sits 1.1-fold (0.02 log units) below what was measured; the measured number falls inside the stated range.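

At this position on an aromatic carbon, the group carried does change the result in this assay: (4-fluorophenyl)amino in place of piperazin-1-yl gives an at least 2.3-fold lower number from compound 2 to compound 3 (0.37 log units; beyond the scatter), and in place of piperidin-1-yl it gives an at least 2.3-fold lower number from compound 1 to compound 3 (0.37 log units; beyond the scatter). Both sizes are lower bounds only, and the step between the two saturated rings still cannot be read. Compound 3 is thus the only compound here with a number of its own, and compound 1 and compound 2 offer no measured baseline for the true size of the change: the limit of > 100000 nM in this assay, at which 2 of the 3 values shown sit.

On these data alone, it remains open whether the fluorine contributes to these steps or whether the aromatic ring and its amino link suffice, a question that plain phenylamino or (4-chlorophenyl)amino at this position would address. As far as these compounds go, how far the value can move with a different group on the aromatic ring, such as methoxy, also stays open.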